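Removing a fluoro from compound 2

The source may report more compounds than this note shows. Statements on the series, on what has been measured and on what is new or still open speak of the compounds shown alone.

Compound 1 `Nc1ccc(-c2nc3cc(F)ccc3s2)cc1`: 29500 nM
Compound 2 `Cc1cc(-c2nc3cccc(F)c3s2)ccc1N`: 1300 nM
Compound 3 `Nc1ccc(-c2nc3cc(F)ccc3s2)cc1I`: 280 nM

In a functional assay on OVCAR-5 cells (Homo sapiens) for inhibition (on this read-out higher numbers stand for weaker inhibition of growth and lower numbers for stronger inhibition of growth), compound 2 sits in the middle of the three. Its 1300 nM is lower than the number for compound 1 and higher than the number for compound 3.

The next compound to consider is compound 4 `Cc1cc(-c2nc3ccccc3s2)ccc1N`, which differs from compound 2 in a single place: hydrogen in place of fluoro on an aromatic carbon. Hydrogen takes the place of fluoro on an aromatic carbon, and the rest of the structure stays the same.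

For the measured compounds named here, no measured step removes a fluoro, so direct evidence is missing. Going by the values given here, the only single-place step measured so far is a 110-fold lower number from compound 1 to compound 3 (2.02 log units; beyond the scatter), and it brings in iodo rather than hydrogen. It shows that one substitution on an aromatic carbon can move the numbers a long way, but it does not tell which way the loss of fluoro will go.

A moderate step towards a lower number in this assay is expected, though this lean is a judgement that no measurement settles. The estimated change is a 2.6-fold lower number from compound 2 to compound 4 (0.41 log units; beyond the scatter). The range stays wide because a 110-fold lower number from compound 1 to compound 3 (2.02 log units; beyond the scatter) is so large. For compound 4 the expected value is 500 nM, with an estimated range of 40 nM to 3000 nM.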

Compound 4, concentration for 50% growth inhibition: 1900 nM
Estimate against measurement, compound 4: 3.8-fold (0.58 log units) below; low and high end bracket the measured number.
By their numbers in this assay, from the lowest: compound 3; then compounds 2 and 4 (each within the scatter of the next); then compound 1.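

In this assay, the swap of fluoro for hydrogen gives a 1.5-fold higher number from compound 2 to compound 4 (0.16 log units; within the scatter), so on this aromatic carbon, ortho to a fused ring, the presence of the fluoro makes no difference that can be told from ordinary repeat-to-repeat variation. For the compounds shown here, this is the first measured step in which a single substitution on an aromatic carbon leaves the read-out within the scatter, whereas the only earlier step, with iodo in place of hydrogen, was a 110-fold lower number from compound 1 to compound 3 (2.02 log units; beyond the scatter); the two steps differ in both the group and its place, so a single aromatic substitution can matter greatly or hardly at all. Nothing available explains why removing this fluoro changes so little.

As far as these compounds go, it remains open whether this carbon tolerates every group equally, since a larger or differently built group, such as a methoxy group, an amine or a nitrile, could give a very different result here. From the compounds shown here alone, it also remains open whether hydrogen in place of fluoro would be equally quiet in the core of compound 3, where iodo is present.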